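The source may report more compounds than this note shows. Statements on the series, on what has been measured and on what is new or still open speak of the compounds shown alone.

The compounds measured in an assay on HEK293 cells for inhibition of Fatty-acid amide hydrolase 1 (Homo sapiens), read by fluorescence (on this read-out higher numbers stand for weaker inhibition and lower numbers for stronger inhibition), are three. Compound 1 `Cn1ccc2cc(-c3ccc4oc(N5CCCC5)nc4c3)ccc21` gives 674 nM. Compound 2 `Cn1ccc2cc(-c3ccc4oc(N5CCNCC5)nc4c3)ccc21` gives > 1000 nM, which is a limit of the assay and not a number. Compound 3 `Cn1ccc2cc(-c3ccc4oc(N5Cc6cccnc6C5)nc4c3)ccc21` gives 211 nM.

Of the two numbers in this assay, compound 3 holds the lower; its nearest neighbour is compound 1, and the step of a 3.2-fold lower number from compound 1 to compound 3 (0.50 log units; beyond the scatter) lies beyond the scatter. Compound 2 stands at the limit of > 1000 nM in this assay, at which 1 of the 3 values shown sits, and the step of an at least 4.7-fold lower number from compound 2 to compound 3 (0.67 log units; beyond the scatter) is likewise at least modest. Compound 4 `Cn1ccc2cc(-c3ccc4oc(N5Cc6ccncc6C5)nc4c3)ccc21` has not yet been measured; it differs from compound 3 by a group of 9 heavy atoms (7 carbon, 2 nitrogen; one five-membered non-aromatic ring with 1 hetero atom, one six-membered aromatic ring with 1 hetero atom) in place of a group of 9 heavy atoms (7 carbon, 2 nitrogen; one five-membered non-aromatic ring with 1 hetero atom, one six-membered aromatic ring with 1 hetero atom), on an aromatic carbon. Both measured steps exchange the whole group on that aromatic carbon for a different one, whereas the change to compound 4 keeps the same atoms and only rearranges them, so neither step speaks directly to it. Compound 4 is therefore expected to stay close to compound 3, with an expected step of a 1.2-fold higher number from compound 3 to compound 4 (0.09 log units; within the scatter) within the scatter. Compound 4 is estimated at 260 nM, with a range from 100 nM to 700 nM.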

Compound 4, half-maximal inhibitory concentration: 121 nM
Estimate against measurement, compound 4: 2.1-fold (0.33 log units) above; measured number inside the range.
By their numbers in this assay, from the lowest: compounds 4 and 3 (each within the scatter of the next); then compound 1. At a limit, above all of these: compound 2.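

In this assay, rearranging the same atoms within the group on the aromatic carbon of the five-membered aromatic ring with 1 nitrogen and 1 oxygen gives a 1.7-fold lower number from compound 3 to compound 4 (0.24 log units; within the scatter), so the two arrangements cannot be told apart at this position. The second arrangement also stands clear of the pyrrolidin-1-yl group, with a 5.6-fold lower number from compound 1 to compound 4 (0.75 log units; beyond the scatter), which shows that the step seen earlier in a 3.2-fold lower number from compound 1 to compound 3 (0.50 log units; beyond the scatter) is not confined to one placement of the nitrogen in the six-membered aromatic ring. Compound 2 holds a limit of the assay and not a number, so an at least 8.2-fold lower number from compound 2 to compound 4 (0.91 log units; beyond the scatter) is only a floor: the limit of > 1000 nM in this assay, at which 1 of the 4 values shown sits.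

Whether that ring nitrogen matters at all stays open, since the same group with only carbon in its six-membered aromatic ring is not among the compounds shown. On these data alone, how a morpholin-4-yl or a dimethylamino group would read at this position is equally open.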